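The compounds below may be only part of what the source reports. "The series", "measured", "known", "first", "only" and "open" are said of these compounds alone.

Measured so far:
compound 1 `COc1cc(O)c2c(=O)cc(-c3ccccc3Cl)oc2c1CN1CCCCC1` — 45500 nM
compound 2 `COc1cc(OC)c(C(=O)/C=C/c2ccccc2Cl)c(O)c1CN(C)CCCN(C)C` — 3100 nM

In a functional assay on A549 cells (Homo sapiens) for antiproliferative activity, with a stated time of 72 h (a lower number here means a stronger inhibitor, a higher number a weaker inhibitor), compound 2 gives the lowest of the two numbers; compound 1, with a different core, gives 45500 nM, a weaker result well beyond the scatter.

Compound 3 `COC(=O)CN(C)Cc1c(OC)cc(OC)c(C(=O)/C=C/c2ccccc2Cl)c1O` keeps the core of compound 2 and changes one thing: methoxycarbonyl in place of 2-(dimethylamino)ethyl on a saturated chain carbon bound to an amine nitrogen. Within the data shown here, no measured pair shows this change, so its effect is unknown. A moderate weakening beyond the scatter is expected, with the step of a 2.6-fold higher number from compound 2 to compound 3 (0.41 log units; beyond the scatter) taken as the estimate. Compound 3 is expected to give 8000 nM, between 2500 nM and 25000 nM.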

Compound 3, half-maximal inhibitory concentration: 9100 nM
Beside the measured number, compound 3's estimate is 1.1-fold (0.06 log units) below it; the range from low to high includes it.
By their numbers in this assay, from the lowest: compound 2; then compound 3; then compound 1.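

In this assay putting methoxycarbonyl in place of 2-(dimethylamino)ethyl on a saturated chain carbon bound to an amine nitrogen gives a 2.9-fold higher number from compound 2 to compound 3 (0.47 log units; beyond the scatter) so the end of this chain does affect the result. The effect is modest, and of these two groups 2-(dimethylamino)ethyl gives the lower number. Nothing available explains this difference.

Still open, on these data alone, is how a carboxylic acid, an amide or a cyclic amine would behave here. A longer chain ending in methoxycarbonyl is equally untested by these compounds.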